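The compounds below may be only part of what the source reports. "The series", "measured", "known", "first", "only" and "open" are said of these compounds alone.

Three analogues sharing a common core have been measured in an in vitro ADME assay on microsomes from liver (Rattus norvegicus) for metabolic stability; on this read-out higher numbers stand for fast clearance and lower numbers for slow clearance. Compound 1 `Cc1cc(C(=O)NCc2ccccc2)nn1Cc1cc(Cl)ccc1OCc1ccccc1` gives 15 mL.min-1.g-1. Compound 2 `Cc1cc(NC(=O)c2ccccc2)nn1Cc1cc(Cl)ccc1OCc1ccccc1` gives 7.3 mL.min-1.g-1, which is the lowest of the three numbers. Compound 3 `Cc1cc(NC(=O)O[C@H]2CCOC2)nn1Cc1cc(Cl)ccc1OCc1ccccc1` gives 11 mL.min-1.g-1. Among the steps, a 2.1-fold lower number from compound 1 to compound 2 (0.31 log units; beyond the scatter) is the only one beyond the scatter; a 1.4-fold lower number from compound 1 to compound 3 (0.13 log units; within the scatter) and a 1.5-fold higher number from compound 2 to compound 3 (0.18 log units; within the scatter) both fall within it. All three of these steps alter the amide portion of the molecule, and none of them touches the methyl-bearing position of the core.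

Compound 4 `O=C(Nc1ccn(Cc2cc(Cl)ccc2OCc2ccccc2)n1)c1ccccc1` is not yet measured in this assay. Relative to compound 2 it differs by hydrogen in place of methyl on an aromatic carbon. For the measured compounds named here, no measured step probes this change. The closest guide is the value of compound 2 itself, 7.3 mL.min-1.g-1, which stands at the low end of the small set. Compound 4 is therefore expected to land close to compound 2 in this assay, with a step of a 1.0-fold higher number from compound 2 to compound 4 (0.01 log units; within the scatter) that is not expected to exceed the scatter in either direction. The estimate for compound 4 in this assay is 7.5 mL.min-1.g-1, with a range from 3.8 mL.min-1.g-1 to 15 mL.min-1.g-1.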

Compound 4, intrinsic clearance in microsomes: 7 mL.min-1.g-1
Estimate against measurement, compound 4: 1.1-fold (0.03 log units) above, and the stated range covers the measured number.
By their numbers in this assay, from the lowest: compounds 4, 2, 3 and 1 (each within the scatter of the next, the first and the last beyond it).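

The step from methyl to hydrogen is the only one shown that touches this position, on the aromatic carbon two ring bonds from the ring atom that bears the benzamido group, and in this assay it gives a 1.0-fold lower number from compound 2 to compound 4 (0.02 log units; within the scatter). The earlier compounds shown here varied only the amide portion and so said nothing about this site; now it is seen that, with the benzamido group in place, the methyl can be replaced by hydrogen without a step beyond the scatter. No measured finding at hand bears on this result, so the step stands as an observation only.

The compounds shown leave open whether other groups on this aromatic carbon, such as an ethyl, a longer chain, an amine or a carboxylic acid, would also stay within the scatter of compound 2. As far as these compounds go, it also remains open whether hydrogen in place of methyl would give a similar step alongside the benzylcarbamoyl group of compound 1 or the (((oxolan-3-yl)oxy)carbonyl)amino group of compound 3.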